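Benzyl ether variation and cell tolerance in the series

A few compounds are considered here, and "the series" means these few. Any claim that something is new, unique, unknown or untested is made for them only; others in the source may bear on it.

Measured compounds: compound 1, `O=c1c(O)c(-c2ccccc2)oc2cc(OCc3ccccc3Cl)cc(O)c12`; compound 2, `O=c1c(O)c(-c2ccccc2)oc2cc(OCc3cccc(Cl)c3)cc(O)c12`; compound 3, `O=c1c(O)c(-c2ccccc2)oc2cc(OCc3ccc(Cl)cc3)cc(O)c12`. Not yet measured: compound 4, `O=c1c(O)c(-c2ccccc2)oc2cc(OCc3ccc([N+](=O)[O-])cc3)cc(O)c12`.

In an ADME assay on Huh-5-2 cells (Homo sapiens) for cytotoxicity, read by WST assay, with a stated time of 3 days (a lower number here means that less compound is tolerated, a higher number that more compound is tolerated), compound 1 gives only a limit, > 100000 nM. Compound 2 likewise gives only a limit in this assay, > 100000 nM. Compound 3 also gives only a limit in this assay, > 100000 nM. Compound 2 thus stands where every other value shown stands, at the limit of > 100000 nM in this assay, at which 3 of the 3 values shown sit. The steps among the measured compounds cannot be sized: a step that the two limits leave unreadable from compound 1 to compound 2, a step that the two limits leave unreadable from compound 1 to compound 3 and a step that the two limits leave unreadable from compound 2 to compound 3 are all left unreadable by the limits.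

Compound 4 differs from compound 2 by 4-nitrophenyl in place of 3-chlorophenyl on a saturated chain carbon bound to an oxygen on an aromatic ring. The step that bears most directly on it, a step that the two limits leave unreadable from compound 2 to compound 3, also moves a group to the same 4-position of the phenyl without a readable change. Because the limit of > 100000 nM in this assay, at which 3 of the 3 values shown sit, holds for all three measured compounds, no step beyond the scatter is expected in this assay. The step from compound 2 to compound 4 is estimated as a number no higher from compound 2 to compound 4 (the limit leaves the size open). Compound 4 is therefore expected at 100000 nM, within 50000 nM to 300000 nM, most likely reported again as a limit rather than a number.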

Compound 4, half-maximal cytotoxic concentration: 93000 nM
Compound 4: the middle estimate sits 1.1-fold (0.03 log units) above what was measured, and the stated range covers the measured number.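

In this assay compound 4 gives 93000 nM, a number rather than a limit, so this position on the saturated chain carbon now has one readable value. Against the chlorinated benzyl ethers the change reads only as a floor: an at least 1.0-fold lower number from compound 3 to compound 4 (0.03 log units; that floor lies within the scatter) for nitro in place of chloro on an aromatic carbon, with an at least 1.0-fold lower number from compound 2 to compound 4 (0.03 log units; that floor lies within the scatter) and an at least 1.0-fold lower number from compound 1 to compound 4 (0.03 log units; that floor lies within the scatter) for the changes from 3-chlorophenyl and 2-chlorophenyl. The steps among the three chlorinated compounds remain unreadable, and 4-nitrophenyl does not separate from the chlorophenyl groups beyond the scatter, so the series stays defined by its limit: the limit of > 100000 nM in this assay, at which 3 of the 4 values shown sit.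

Open, going by these compounds, is whether any group at this place moves the number beyond the scatter, for instance an amine or a carboxylic acid on the phenyl ring, or a longer chain in place of the saturated chain carbon. On these data alone, how changes on the shared core itself would read in this assay also stays open.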